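Thioamide in place of the amide on a short chain

A few compounds are considered here, and "the series" means these few. Any claim that something is new, unique, unknown or untested is made for them only; others in the source may bear on it.

Compound 1, `NC(=O)CCn1nc(-c2ccccc2)ccc1=O`, carries a carbamoylmethyl chain on the nitrogen of the shared core. Going by the values given here, in a functional assay on the whole organism (stomach) for inhibition, with Rattus norvegicus as the target, at a dose of 100 mg/kg by the intraduodenal route (on this read-out higher numbers stand for more inhibition at the one dose given (going by the name of the read-out) and lower numbers for less inhibition), compound 1 gives -2.8%, the lowest of the three numbers measured so far. Compound 2, `N=C(S)CCCCCCn1nc(-c2ccccc2)ccc1=O`, gives 33.9%, and compound 3, `C/N=C(/S)CCCCCn1nc(-c2ccccc2)ccc1=O`, gives 92.3%.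

The two measured steps that bear on the present question both replace the amide-bearing group of compound 1 with a sulfur-bearing group on a saturated chain: a number 36.7 percentage points higher from compound 1 to compound 2 (beyond the scatter) and a number 95.1 percentage points higher from compound 1 to compound 3 (beyond the scatter). A further step, a number 58.4 percentage points higher from compound 2 to compound 3 (beyond the scatter), exchanges one sulfur-bearing end group for another of the same size.

Compound 4, `CC(Cn1nc(-c2ccccc2)ccc1=O)C(=N)S`, makes a related change to compound 1: a group of 5 heavy atoms (3 carbon, 1 nitrogen, 1 sulfur; no ring) in place of a group of 4 heavy atoms (2 carbon, 1 nitrogen, 1 oxygen; no ring), on a saturated chain carbon bound to an aromatic nitrogen. The entering group again carries sulfur in place of oxygen, as in the two large upward steps, but here the chain stays short, unlike the long chains of compound 2 and compound 3. The step is therefore expected to be upward in this assay, though of uncertain size, estimated as a number 37.8 percentage points higher from compound 1 to compound 4 (beyond the scatter). For compound 4 the expected value in this assay is 35%, within a range from 5% to 70%.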

Compound 4, a percentage reported as inhibition, in the whole organism at one dose (the size of the read-out at that dose, not a potency): 86.4%
The estimate for compound 4 lay 51.4 percentage points below the measured number, and the stated range ends below it.
By their numbers in this assay, from the lowest: compound 1; then compound 2; then compounds 4 and 3 (each within the scatter of the next).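

In this assay, the change gives a number 89.2 percentage points higher from compound 1 to compound 4 (beyond the scatter), so on a saturated chain carbon bound to an aromatic nitrogen, a sulfur-bearing group in place of carbamoylmethyl can go with a large rise even when the chain stays short. The earlier large upward steps came only with long chains, whereas compound 4 gives 86.4% and compound 3 gives 92.3%, two values within the scatter of each other; among these compounds a long chain is therefore not needed for a high number, and compound 2, which has a long chain yet gives only 33.9%, goes against any simple link between chain length and inhibition. Nothing available here explains the size of the rise.

The compounds shown leave open how much of the step belongs to the sulfur and how much to the extra carbon of the entering group, as compound 1 and compound 4 differ in both. They also do not show how a carboxylic acid or an amine at the end of the same short chain would behave.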